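This account rests on a few compounds, and the source may have more. Where it says the series, first, only, none or still open, it means among the compounds named here.

Compound 1 `COc1cc(N2C(=S)SCC2(O)c2ccc(Cl)cc2Cl)cc(OC)c1OC` gives 16.9 ug/mL in a functional assay on T47D cells (Homo sapiens) for cytotoxicity, read by MTT assay, with a stated time of 48 h; a higher number here means a weaker inhibitor, a lower number a stronger inhibitor. Compound 2 `COc1cc(-n2c(-c3ccc(Br)cc3)csc2=S)cc(OC)c1OC` is different in kind: in this assay it reaches only (the limit of > 100 ug/mL in this assay, at which 1 of the 2 values shown sits), so its value of > 100 ug/mL is a limit and not a number. Compound 3 `COc1cc(-n2c(-c3ccc(-c4ccccc4)cc3)csc2=S)cc(OC)c1OC` differs from compound 2 by phenyl in place of bromo on an aromatic carbon. Among the compounds with values here, with compound 2 known only as a limit, no measured step guides this change, and no shift beyond the usual scatter is expected in this assay. Compound 3 is therefore estimated at 90 ug/mL, with a range from 30 ug/mL to 200 ug/mL. The expected step is an at least 1.1-fold lower number from compound 2 to compound 3 (0.04 log units; that floor lies within the scatter).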

Compound 3, half-maximal inhibitory concentration: > 100 ug/mL
Compound 3 gave a limit, no number; the forecaster's own chance of this, stated with the estimate: 55%; middle value at least 1.1-fold (0.04 log units) away from the limit.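

Compound 3, like compound 2, gives a limit and not a number, so no step between the two can be read: the limit of > 100 ug/mL in this assay, at which 2 of the 3 values shown sit.

As far as these compounds go, whether phenyl in place of bromo shifts the value at all remains open.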